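Methyl in Place of Methoxy: What Compound 3 Might Show

The source may hold more compounds than are shown below. What is called first, only, known or untested is meant among the compounds shown, and "the series" means these compounds.

Measured compounds:
compound 1, `COc1cc(Cl)nc(NC(=S)NC(=O)c2c(-c3ccc(Cl)cc3Cl)noc2C)n1`, 30.7%;
compound 2, `COc1cc(C)nc(NC(=S)NC(=O)c2c(-c3ccc(Cl)cc3Cl)noc2C)n1`, 15.7%.

Of the compounds shown here, two have been measured in a functional assay on the whole organism for inhibition, with Brassica napus as the target, with a stated time of 72 h, tested at 10 mg/L; a lower number here means less inhibition of growth, a higher number more inhibition of growth at the concentration tested. Compound 1 gives 30.7%. Compound 2 gives 15.7%, the lowest of the two numbers, and its nearest neighbour is compound 1, which lies higher by a margin beyond the scatter. Among the measured compounds shown here, the one measured step, a number 15 percentage points lower from compound 1 to compound 2 (beyond the scatter), is modest and concerns methyl in place of chloro on an aromatic carbon.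

Compound 3, `Cc1cc(C)nc(NC(=S)NC(=O)c2c(-c3ccc(Cl)cc3Cl)noc2C)n1`, has not yet been measured. It differs from compound 2 as follows: methyl in place of methoxy on an aromatic carbon. For the measured compounds named here, no measured step concerns this change; the step from compound 1 to compound 2 replaces a different group and so does not bear on it directly. With nothing to point either way, the step of a number 0.7 percentage points lower from compound 2 to compound 3 (within the scatter) is expected to stay within the scatter. Compound 3 is therefore estimated to give 15%, in a range from 4% to 30%.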

Compound 3, percent growth inhibition at one concentration: 16.1%
Beside the measured number, compound 3's estimate is 1.1 percentage points below it; measured number inside the range.
By their numbers in this assay, from the lowest: compounds 2 and 3 (each within the scatter of the next); then compound 1.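

In this assay, methyl in place of methoxy on this aromatic carbon of the six-membered aromatic ring with 2 nitrogen gives a number 0.4 percentage points higher from compound 2 to compound 3 (within the scatter), so with a methyl group on the same ring, this assay does not tell the two groups apart. Among the compounds shown here, this is the first reading at this position, since the earlier step concerned the chloro group and left the methoxy untouched. The step of a number 14.6 percentage points lower from compound 1 to compound 3 (beyond the scatter) changes two places at once, yet it reads much like a number 15 percentage points lower from compound 1 to compound 2 (beyond the scatter), so among these three compounds the one carrying chloro stands apart from the two carrying a methyl group in its place, while no measurement shown here gives a reason for either result.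

The compounds shown leave open whether an amine such as dimethylamino, or a longer chain such as ethoxy or propyl, would also read alike at this position. They also leave open whether methyl and methoxy would still read alike with chloro rather than methyl as the other group on the ring, a pairing that 4-chloro-6-methylpyrimidin-2-yl would supply.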